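The source may hold more compounds than are shown below. What is called first, only, known or untested is meant among the compounds shown, and "the series" means these compounds.

Compound 1 `Nc1nc(Cl)c2ncn(Cc3ccc(CCl)cc3)c2n1`: 1860 nM
Compound 2 `ClCc1cccc(Cn2cnc3nc(Cl)nc(Cl)c32)c1`: 2130 nM
Compound 3 `ClCc1ccccc1Cn1cnc2nc(Cl)nc(Cl)c21`: 3010 nM

All three were tested in a functional assay on SF-268 cells (Homo sapiens) for cytotoxicity, read by sulforhodamine B assay, with a stated time of 48 h; a lower number here means a stronger inhibitor of growth, a higher number a weaker inhibitor of growth. Compound 3 gives the highest of the three numbers, yet its distances to compound 2 and to compound 1 both lie within the usual scatter of repeated measurements, so the three cannot be ranked against one another. Compound 4 `ClCc1ccccc1Cn1cnc2ncnc(Cl)c21` has not yet been measured. It differs from compound 3 in one place: hydrogen in place of chloro on an aromatic carbon. Among the measured compounds shown here, no measured pair shows what this change does, so the expectation rests on the change being a single heavy atom leaving. The step of a 1.4-fold higher number from compound 3 to compound 4 (0.14 log units; within the scatter) is expected to be small, toward a somewhat higher number or none beyond the scatter. Compound 4 is estimated at 4200 nM, within a range from 1500 nM to 12000 nM.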

Compound 4, concentration for 50% growth inhibition: 4780 nM
Estimate against measurement, compound 4: 1.1-fold (0.06 log units) below, and the stated range covers the measured number.
By their numbers in this assay, from the lowest: compounds 1, 2, 3 and 4 (each within the scatter of the next, the first and the last beyond it).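

In this assay, among the compounds shown here, replacing the chloro group between two ring nitrogen atoms with hydrogen gives a 1.6-fold higher number from compound 3 to compound 4 (0.20 log units; within the scatter) and provides the first measured pair for this change. At this position, the chloro group can therefore be absent without a difference that can be told from ordinary assay scatter. Nothing measured here offers an explanation for this result. Still open, from the compounds shown here alone, is whether a methoxy or methyl group on this same carbon would give a difference beyond the scatter. Going by these compounds, the effect of replacing the remaining chloro group, meta to this position, also remains unknown.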